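The source may report more compounds than this note shows. Statements on the series, on what has been measured and on what is new or still open speak of the compounds shown alone.

Compound 1 `Cc1cccc(CSc2cc(Cl)c(C)cc2S(=O)(=O)/N=C(\N)n2nccc2-c2ccccc2)c1` gives 8000 nM; compound 2 `Cc1cc(S(=O)(=O)/N=C(\N)n2nccc2-c2ccccc2)c(SCc2cccc(Cl)c2)cc1Cl` gives 10000 nM; compound 3 `Cc1cc(-c2ccccc2)n(/C(N)=N/S(=O)(=O)c2cc(C)c(Cl)cc2SCc2ccccc2C)n1` gives 160000 nM in a functional assay on HeLa cells (Homo sapiens) for cytotoxicity, read by MTT assay, with a stated time of 72 h; a lower number here means a stronger inhibitor, a higher number a weaker inhibitor.

Compound 3 stands highest of the three. Compound 4 `Cc1cc(S(=O)(=O)/N=C(\N)n2nccc2-c2ccccc2)c(SCc2ccccc2C)cc1Cl` differs from it by hydrogen in place of methyl on an aromatic carbon. For the measured compounds named here, no measured step touches this position; the only measured step, a 1.3-fold higher number from compound 1 to compound 2 (0.10 log units; within the scatter), changes a substituent on the benzyl group instead. Compound 4 carries the same core as compounds 1 and 2, which both read far lower than compound 3, so compound 4 is expected to move toward them, with the step of an 11-fold lower number from compound 3 to compound 4 (1.03 log units; beyond the scatter) taken as an estimate. Compound 4 is therefore estimated at 15000 nM, within 4000 nM to 60000 nM.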

Compound 4, half-maximal inhibitory concentration: 17000 nM
Beside the measured number, compound 4's estimate is 1.1-fold (0.05 log units) below it, within the range that was stated.
By their numbers in this assay, from the lowest: compounds 1, 2 and 4 (each within the scatter of the next, the first and the last beyond it); then compound 3.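

In this assay, hydrogen in place of methyl on this aromatic carbon, two ring bonds from the ring atom that bears a phenyl group, brings a clear drop (a 9.4-fold lower number from compound 3 to compound 4 (0.97 log units; beyond the scatter)), the first measured sign that this position matters. Changes on the saturated chain carbon bound to a sulfur give smaller steps (a 1.7-fold higher number from compound 2 to compound 4 (0.23 log units; within the scatter); a 2.1-fold higher number from compound 1 to compound 4 (0.33 log units; beyond the scatter)). Nothing at hand gives a reason for the effect of the methyl.

Going by these compounds, how an ethyl, an amine or a carboxylic acid on this carbon would read remains open. So does whether methyl here has the same effect alongside 3-chlorophenyl or 3-methylphenyl.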